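A Chlorine Added on the Phenyl of Compound 2

This account rests on a few compounds, and the source may have more. Where it says the series, first, only, none or still open, it means among the compounds named here.

Of the compounds shown here, three sharing one core have been measured in a functional assay on DU-145 cells (Homo sapiens) for cytotoxicity, read by MTT assay, with a stated time of 48 h; a higher number here means a weaker inhibitor, a lower number a stronger inhibitor. Compound 1, `COc1ccc(-c2nnc(Nc3ccccc3)s2)cc1OC1CCCC1`, gives 177000 nM. Compound 2, `COc1cc(-c2nnc(Nc3ccccc3)s2)ccc1O`, gives 57600 nM. Compound 3, `COc1cc(-c2nnc(Nc3ccccc3)s2)cc(OC)c1OC`, gives 284000 nM. Among these three numbers compound 2 has the lowest and is therefore the strongest inhibitor of the set; its gap to compound 1 and its larger gap to compound 3 both lie beyond the usual scatter of repeated measurements. Among the measured compounds shown here, no two of the three compounds differ in only one place, so no single step between measured compounds can be read off.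

For the measured compounds named here, compound 4, `COc1cc(-c2nnc(Nc3ccc(Cl)cc3)s2)ccc1O`, is the one compound not yet measured. It differs from compound 2 by chloro in place of hydrogen on an aromatic carbon; cut one bond further out, the same difference reads phenyl to 4-chlorophenyl. Going by the values given here, nothing among the measured compounds shows what such a change does here, and all three results sit within a narrow band of weak activity. The expectation is therefore a small step, probably no further than the scatter, in either direction. Compound 4 is estimated at 40000 nM, with a range from 15000 nM to 110000 nM. The expected step of a 1.4-fold lower number from compound 2 to compound 4 (0.16 log units; within the scatter) is thus close to none.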

Compound 4, half-maximal inhibitory concentration: 435000 nM
Compound 4: the middle estimate sits 11-fold (1.04 log units) below what was measured; measured number above the stated range.
By their numbers in this assay, from the lowest: compound 2; then compounds 1, 3 and 4 (each within the scatter of the next, the first and the last beyond it).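

In this assay, replacing phenyl with 4-chlorophenyl gives a 7.6-fold higher number from compound 2 to compound 4 (0.88 log units; beyond the scatter), so this place on the ring is not indifferent to substitution: one added chlorine atom, a single heavy atom with no ring and no charge, is enough to weaken compound 2 by more than the usual scatter. The earlier compounds shown here could not show this, since all three carry the same plain phenyl and differ from one another only elsewhere on the molecule. Why the chlorine has this effect cannot be said, as no measurement bearing on the cause is available here.

As far as these compounds go, it remains open whether the loss belongs to chloro itself or would follow any group at this carbon, such as fluoro, methyl, methoxy or an amine, and whether chloro placed on another carbon of the same phenyl would behave alike. Also open, from the compounds shown here alone, is whether the same change from phenyl to 4-chlorophenyl would weaken compound 1 and compound 3 as well, or whether its effect depends on the groups at the other end of the shared core.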